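This account rests on a few compounds, and the source may have more. Where it says the series, first, only, none or still open, it means among the compounds named here.

Three compounds sharing one core have been examined in an ADME assay on CHO cells (Cricetulus griseus) for cytotoxicity, read by LDH release; a higher number here means a weaker inhibitor, a lower number a stronger inhibitor. For compound 1 `CC(Oc1ccc(Cl)cc1Cl)C(=O)NC(c1ccc(F)cc1)C1CCC1`, the assay returned a limit and not a number: > 100000 nM. For compound 2 `CC(Oc1ccc(Cl)cc1Cl)C(=O)Nc1ccc(F)cc1`, the entry reads "not determined" (no result reported). Among the compounds with values here, compound 3 `CC(Oc1ccc(Cl)cc1Cl)C(=O)NCc1ccccc1`, at 95000 nM, therefore holds the only actual number in this assay, which leaves it without a measured neighbour to be ranked against.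

Compound 4 `Cc1ccccc1CNC(=O)C(C)Oc1ccc(Cl)cc1Cl` departs from compound 3 by one small edit, methyl in place of hydrogen on an aromatic carbon, ortho to a large group, so that phenyl becomes 2-methylphenyl. No measured step among these compounds shows what such an edit does in this assay. The expectation is therefore for no change beyond the usual scatter, and the estimated step is a 1.1-fold lower number from compound 3 to compound 4 (0.05 log units; within the scatter). A report of compound 4 as a limit of the assay would also come as no surprise. For compound 4, the estimated value is 85000 nM, with an expected range of 40000 nM to 160000 nM.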

Compound 4, half-maximal inhibitory concentration: > 100000 nM
Compound 4 was reported as a limit; the forecaster's own chance of this, stated with the estimate: 45%; middle value at least 1.1-fold (0.07 log units) from the limit.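

In this assay, within the data shown here, the change from phenyl to 2-methylphenyl gives the first readable step at this position, an at least 1.0-fold higher number from compound 3 to compound 4 (0.02 log units; that floor lies within the scatter), and a methyl on this aromatic carbon, ortho to a large group, gives no sign of a stronger inhibitor. Compound 4 is reported only as a limit of the assay, so this step has a floor and no upper end, and its full size cannot be read. That limit recurs among the compounds shown: the limit of > 100000 nM in this assay, at which 2 of the 4 values shown sit.

The compounds shown leave open whether another group on this aromatic carbon, such as ethyl, methoxy, chlorine or an amine, would give a measurable number in this assay. They also leave open what a methyl does on the other carbons of this ring, since only this one place is covered.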